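This account rests on a few compounds, and the source may have more. Where it says the series, first, only, none or still open, it means among the compounds named here.

Two compounds of this series have been taken through a toxicity assay on the whole organism (strain Icem-CET (SPF Caw)) for cytotoxicity, with Mus musculus as the target (on this read-out lower numbers stand for an effect already at smaller amounts and higher numbers for an effect only at larger amounts of compound), so far. Compound 1 `C/C(C(=O)NC1CC1)=C(/C)c1ccc(F)cc1` gives 110 mg/kg in this assay. Compound 2 `C#CCNC(=O)/C(C)=C(\C)c1ccc(C)cc1` gives 120 mg/kg in this assay. Compound 2 stands at the upper end of the two numbers, but its distance from compound 1 is within the usual scatter, so the two cannot be told apart on this read-out. Among the measured compounds shown here, no single-point step between measured compounds is available.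

Compound 3 `C#CCNC(=O)/C(C)=C(\C)c1ccc(F)cc1` is the next member awaiting a number in this assay. Relative to compound 2 it carries fluoro in place of methyl on an aromatic carbon, the fluoro in place of methyl on an aromatic carbon of the shared core. For the measured compounds named here, the only measured compound that carries a fluoro on the same ring is compound 1, which differs from compound 3 elsewhere as well, so its value is a reference point rather than a direct step.

No step beyond the scatter is expected from compound 2 to compound 3 in this assay, in either direction; the step is estimated as a 1.0-fold lower number from compound 2 to compound 3 (0.02 log units; within the scatter). Compound 3 is accordingly estimated at 115 mg/kg in this assay, with a range from 60 mg/kg to 230 mg/kg.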

Compound 3, dose for half-maximal effect: 100 mg/kg
The estimate for compound 3 lay 1.2-fold (0.06 log units) above the measured number, within the range that was stated.
By their numbers in this assay, from the lowest: compounds 3, 1 and 2 (each within the scatter of the next).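

In this assay, among the compounds shown here, fluoro in place of methyl on an aromatic carbon, para to a large group, gives a 1.2-fold lower number from compound 2 to compound 3 (0.08 log units; within the scatter) with the propargyl amide held constant; this is the first single-place reading at this position, and the two groups cannot be told apart there on this read-out. For the compounds shown here, with the fluoro held constant, propargyl in place of cyclopropyl on an amide-type nitrogen gives a 1.1-fold lower number from compound 1 to compound 3 (0.04 log units; within the scatter) and so also yields no separable step, which extends the same reading to a second place on the shared core. No supporting data bear on either of these two steps.

The three compounds span only methyl and fluoro on the ring and propargyl and cyclopropyl on the nitrogen, so the flatness holds for these groups alone and says nothing yet about how far either place tolerates change. From the compounds shown here alone, whether a methoxy group or a carboxylic acid on the ring, or a longer chain or a terminal amine on the amide nitrogen, would give a step beyond the scatter remains open.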